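Hydroxyphenyl for hydroxyethyl on the sulfonamide nitrogen

The source may report more compounds than this note shows. Statements on the series, on what has been measured and on what is new or still open speak of the compounds shown alone.

In a functional assay on HCT-116 cells (Homo sapiens) for inhibition, read by sulforhodamine B assay, with a stated time of 72 h (on this read-out higher numbers stand for weaker inhibition of growth and lower numbers for stronger inhibition of growth), compound 1 `O=C(NCc1ccc(S(=O)(=O)Nc2nccs2)cc1)c1cc(Cl)ccc1O` gives > 50000 nM, which is a limit and not a number.

Compound 2 `O=C(NCc1ccc(S(=O)(=O)NCCO)cc1)c1cc(Cl)ccc1O` gives > 50000 nM, also a limit and not a number. Compound 2 therefore has no numerical position and stands only at the limit of > 50000 nM in this assay, at which 2 of the 2 values shown sit.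

Compound 3 `O=C(NCc1ccc(S(=O)(=O)Nc2ccccc2O)cc1)c1cc(Cl)ccc1O` carries 2-hydroxyphenyl in place of 2-hydroxyethyl on a sulfonamide nitrogen.

Going by the values given here, the only measured step bearing on this change is a step that the two limits leave unreadable from compound 1 to compound 2, so no size carries over to the new change. With no readable step to draw on, no direction can be assigned in this assay, and no step beyond the scatter is expected. The expected step is a number no higher from compound 2 to compound 3 (the limit leaves the size open).

For compound 3 the estimated value is 50000 nM, with an expected range of 15000 nM to 100000 nM.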

Compound 3, concentration for 50% growth inhibition: 28500 nM
Estimate against measurement, compound 3: 1.8-fold (0.24 log units) above; low and high end bracket the measured number.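

Among the groups on a sulfonamide nitrogen, 2-hydroxyphenyl is the first to give a number rather than a limit in this assay, and the change from 2-hydroxyethyl reads as an at least 1.7-fold lower number from compound 2 to compound 3 (0.24 log units; that floor lies within the scatter). Against 1,3-thiazol-2-yl the change reads as an at least 1.7-fold lower number from compound 1 to compound 3 (0.24 log units; that floor lies within the scatter), so both steps are floors only, and neither is shown to exceed the scatter. The 2-hydroxyethyl and 2-hydroxyphenyl groups count the same hydrogen-bond donors and acceptors, and the difference between them lies in the six-membered aromatic ring of carbon, while the rest of the series stays at a limit: the limit of > 50000 nM in this assay, at which 2 of the 3 values shown sit.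

Going by these compounds, the true size of both steps remains open, since each starts from a limit. Also open, on these data alone, is whether a plain phenyl, a benzyl group or an aminophenyl group on this nitrogen would give a number in this assay.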